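This account rests on a few compounds, and the source may have more. Where it says the series, first, only, none or still open, it means among the compounds named here.

Working notes on the amide series

Three compounds of this set have a number. Compound 1 `O=C(Nc1nn[nH]n1)c1cccnc1` gives 4% in a functional assay on the whole organism for inhibition, with Rattus norvegicus as the target, at a dose of 3 mg/kg by the oral route; on this read-out higher numbers stand for a stronger effect at the one dose given and lower numbers for a weaker effect. Compound 2 `O=C(Nc1nn[nH]n1)c1cc(Br)ccn1` gives 34% in this assay, and compound 3 `O=C(Nc1nn[nH]n1)c1cccc(Cl)n1` gives 18% in this assay. On these three numbers compound 2 stands highest; the nearest is compound 3, lower by a gap that lies beyond the usual scatter, and the furthest is compound 1, lower by a gap that also lies beyond it. Going by the values given here, no pair among the three differs in only one place, so no single step between measured compounds is available.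

The next compound, compound 4 `Cc1ccnc(C(=O)Nc2nn[nH]n2)c1`, is reached from compound 2 by one change: methyl in place of bromo on an aromatic carbon. The methyl takes the place of the bromo on an aromatic carbon of the six-membered aromatic ring with one nitrogen, meta to a group of 8 heavy atoms and opposite the ring nitrogen. Among the compounds with values here, nothing measured so far shows what a methyl at this place does; the only anchor is compound 2 with its 34% in this assay.

The step from compound 2 to compound 4 is expected to be a small drop, a number 10 percentage points lower from compound 2 to compound 4 (within the scatter), near the edge of the scatter. Compound 4 is therefore estimated to give about 24% in this assay, with a range from 6% to 40%.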

Compound 4, a percentage reported as inhibition, in the whole organism at one dose (the size of the read-out at that dose, not a potency): 42%
Beside the measured number, compound 4's estimate is 18 percentage points below it; the measured number lies above the stated range.
By their numbers in this assay, from the lowest: compound 1; then compound 3; then compounds 2 and 4 (each within the scatter of the next).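

In this assay, methyl in place of bromo on the aromatic carbon opposite the ring nitrogen gives a number 8 percentage points higher from compound 2 to compound 4 (within the scatter) and so stays within the scatter. Going by these compounds alone, this is the only single-place step so far, and it shows that bromo is not needed at this place to keep the effect at the one dose given: on this read-out, the two groups cannot be told apart. The data offer no measured basis for explaining why the exchange leaves the number within the scatter.

The compounds shown leave open whether this tolerance at the place opposite the ring nitrogen extends beyond bromo and methyl, for example to an amine, a carboxylic acid or a longer chain such as propyl. They also leave open whether the same exchange of bromo for methyl would behave in the same way on another aromatic carbon of the ring, and, as every number comes from a single dose, how the two compounds would compare in potency.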